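This account rests on a few compounds, and the source may have more. Where it says the series, first, only, none or still open, it means among the compounds named here.

Compounds measured so far in a functional assay on thoracic aorta for inhibition of Voltage-gated L-type calcium channel (Rattus norvegicus); a higher number here means a weaker inhibitor, a lower number a stronger inhibitor:
compound 1 `CC1=NC(C)=C(C(=O)O)C(c2cccc(F)c2)/C1=C(\O)OC/C=C/c1ccccc1` gives 20 nM; compound 2 `CC1=NC(C)=C(C(=O)O)C(c2cccc(I)c2)/C1=C(\O)OC/C=C/c1ccccc1` gives 13 nM; compound 3 `CC1=NC(C)=C(C(=O)O)C(c2cccc(Cl)c2)/C1=C(\O)OC/C=C/c1ccc(Cl)cc1` gives 5.8 nM.

Compound 3 holds the lowest number of the three. Against compound 2 the gap is beyond the scatter, and against compound 1 it is wider still; compound 3 differs from compound 2 in two places at once, so its two values are compared as they stand, with no single step attached.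

Compound 4 `CC1=NC(C)=C(C(=O)O)C(c2cccc(Cl)c2)/C1=C(\O)OCc1ccc2ccccc2c1` is not yet measured. Relative to compound 3 the change is naphthalen-2-yl in place of 2-(4-chlorophenyl)ethenyl on a saturated chain carbon bound to an oxygen on an unsaturated carbon.

Among the compounds with values here, the only measured single step is a 1.5-fold lower number from compound 1 to compound 2 (0.19 log units; within the scatter), a halogen swap on the other aromatic ring, within the scatter; it does not touch the ester side that changes here. Within the data shown here, no measured step bears directly on exchanging the chain-bearing aryl group for a fused ring system. The expectation is therefore a move of modest size, if any, with the direction uncertain: the estimated step is a 1.4-fold higher number from compound 3 to compound 4 (0.14 log units; within the scatter). Compound 4 is estimated at 8 nM, with a range from 2.5 nM to 25 nM in this assay.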

Compound 4, half-maximal inhibitory concentration: 14 nM
Compound 4: middle estimate off by 1.8-fold (0.24 log units), on the low side; low and high end bracket the measured number.
By their numbers in this assay, from the lowest: compound 3; then compounds 2, 4 and 1 (each within the scatter of the next).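

In this assay, within the data shown here, the side bearing the ester oxygen responds to change: a 2.4-fold higher number from compound 3 to compound 4 (0.38 log units; beyond the scatter) is beyond the scatter, whereas the only earlier single step, on the other aromatic ring, stayed within it. Compound 4 still gives 14 nM with naphthalen-2-yl on the saturated chain carbon, so the double bond and chlorine of 2-(4-chlorophenyl)ethenyl are not required for activity at this level. No available evidence accounts for the size or direction of this step.

This single step replaces the double bond, the chlorine and the single aromatic ring together, so their separate contributions remain unresolved. Also open, going by these compounds, is how a plain phenyl, naphthalen-1-yl or a dimethylamino-bearing chain would behave at this carbon.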